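The source may report more compounds than this note shows. Statements on the series, on what has been measured and on what is new or still open speak of the compounds shown alone.

Compound 2 `CCOC(=O)c1cccc(-c2ccc(CN3CCCC3)cc2)c1` stands at the lower end of the two numbers measured in an assay on COS-7 cells for inhibition of patatin-like phospholipase domain-containing protein 2 (Mus musculus), tested at 200 uM (a higher number here means more inhibition at the concentration tested (going by the name of the read-out), a lower number less inhibition), where compound 2 gives 33% while compound 1 `CCOC(=O)c1cccc(-c2ccc(OCC)cc2)c1` gives 87%. For the measured compounds named here, the only measured step, a number 54 percentage points lower from compound 1 to compound 2 (beyond the scatter), concerns a different change and does not bear on the one taken here. Compound 3 `CCOC(=O)c1cccc(-c2ccc(CN3CCCCC3)cc2)c1` carries piperidin-1-yl in place of pyrrolidin-1-yl on a saturated chain carbon bound to an aromatic carbon. With no measured step of this kind in the series, no step beyond the scatter is expected, so the expected step in this assay is a number 2 percentage points higher from compound 2 to compound 3 (within the scatter). Compound 3 is therefore estimated at 35%, within a range from 15% to 60%.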

Compound 3, a percentage reported as inhibition, at one concentration (the size of the read-out at that concentration, not a potency): 68%
Estimate against measurement, compound 3: 33 percentage points below; measured number outside the range, above it.
By their numbers in this assay, from the lowest: compound 2; then compound 3; then compound 1.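

In this assay, the group on the saturated chain carbon bound to an aromatic carbon proves sensitive to ring size: piperidin-1-yl in place of pyrrolidin-1-yl gives a number 35 percentage points higher from compound 2 to compound 3 (beyond the scatter) for a difference of a single ring carbon. Against the ethoxy group, (piperidin-1-yl)methyl still leaves a number 19 percentage points lower from compound 1 to compound 3 (beyond the scatter), so the six-membered ring narrows the gap without closing it. No measured evidence explains this ring-size difference.

From the compounds shown here alone, whether azepan-1-yl or morpholin-4-yl would extend or reverse the step remains open. So does whether any amine at this place can match ethoxy.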